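Removing one trifluoromethyl group: compound 3 to compound 4

The source may report more compounds than this note shows. Statements on the series, on what has been measured and on what is new or still open speak of the compounds shown alone.

For the measured compounds named here, in a functional assay on L1210 cells (Mus musculus) for inhibition, read by MTT assay, with a stated time of 72 h (a lower number here means a stronger inhibitor, a higher number a weaker inhibitor), compound 3 (`COc1cc(NC(C)CCCNC(=O)Nc2cc(C(F)(F)F)cc(C(F)(F)F)c2)c2ncccc2c1`) gives 3500 nM, the lowest of the three numbers so far. Compound 1 (`COc1cc(NC(C)CCCNC(=O)Nc2cccc(F)c2)c2ncccc2c1`) gives 19000 nM, and compound 2 (`COc1cc(NC(C)CCCNC(=O)NNC(=O)Nc2ccc(F)cc2)c2ncccc2c1`) gives 104000 nM. Compound 3 is therefore the strongest inhibitor measured in this small set.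

The next compound, compound 4 (`COc1cc(NC(C)CCCNC(=O)Nc2cccc(C(F)(F)F)c2)c2ncccc2c1`), keeps the shared core and differs from compound 3 in one place: hydrogen in place of trifluoromethyl on an aromatic carbon. This is hydrogen in place of trifluoromethyl on an aromatic carbon, and one trifluoromethyl group stays on that ring.

Going by the values given here, the only measured step, a 5.5-fold higher number from compound 1 to compound 2 (0.74 log units; beyond the scatter), is modest and replaces 3-fluorophenyl with ((4-fluorophenyl)carbamoyl)amino. Among the compounds with values here, it bears only loosely on this change, showing only that a change on that amide-type nitrogen can move the number beyond the scatter. A closer guide is compound 1, which has 3-fluorophenyl on that nitrogen and stands at 19000 nM. Compound 4 is expected to fall near the range spanned by that number and the number of compound 3. A modest move towards weaker inhibition is expected, an estimated 2.6-fold higher number from compound 3 to compound 4 (0.41 log units; beyond the scatter). For compound 4 the estimated value is 9000 nM, with an expected range of 4000 nM to 22000 nM.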

Compound 4, half-maximal inhibitory concentration: 9200 nM
For compound 4 the middle estimate is 1.0-fold (0.01 log units) below the measured one; the range from low to high includes it.
By their numbers in this assay, from the lowest: compound 3; then compound 4; then compound 1; then compound 2.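

In this assay, the second trifluoromethyl group on the ring counts: hydrogen in its place gives a 2.6-fold higher number from compound 3 to compound 4 (0.42 log units; beyond the scatter), a modest loss even though one trifluoromethyl group stays on that ring. For the compounds shown here, the ring substituent also matters when only one group is present, as trifluoromethyl in place of fluoro gives a 2.1-fold lower number from compound 1 to compound 4 (0.31 log units; beyond the scatter), so this aromatic substitution now has two one-place steps, and both are modest and beyond the scatter. The larger difference lies on the amide-type nitrogen, where 3-(trifluoromethyl)phenyl in place of ((4-fluorophenyl)carbamoyl)amino gives an 11-fold lower number from compound 2 to compound 4 (1.05 log units; beyond the scatter), which outweighs either ring step and marks the extended carbamoyl-amino group as the least favourable of the groups shown at that nitrogen. No measured evidence bears on what lies behind these steps.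

The compounds shown leave open whether trifluoromethyl is specifically favoured on this ring or whether a chloro, nitrile or carboxylic acid group on the same aromatic carbon would give a similar number. They also leave open how a longer chain in the linker would combine with the ring substituents.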